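This account rests on a few compounds, and the source may have more. Where it says the series, first, only, none or still open, it means among the compounds named here.

Compound 1 `COc1ccccc1/C=C/C(=O)/C=C/c1ccc(OCc2cn(CCCCOc3cc(=O)oc4ccccc34)nn2)c(OC)c1` is the starting point. In a functional assay on THP-1 cells (Homo sapiens) for inhibition, read by sulforhodamine B assay, with a stated time of 48 h, tested at 50 uM (on this read-out lower numbers stand for less inhibition of growth and higher numbers for more inhibition of growth at the one concentration tested), compound 1 gives 40%; this is the second highest of the three numbers recorded. Compound 3 `COc1cc(/C=C/C(=O)/C=C/c2ccco2)ccc1OCc1cn(CCCCCOc2cc(=O)oc3ccccc23)nn1` gives 39%, a value within the scatter of compound 1, while compound 2 `COc1cc(/C=C/C(=O)/C=C/c2cc(OC)c(OC)c(OC)c2)ccc1OCc1cn(CCCCCOc2cc(=O)oc3ccccc23)nn1` gives 55%, which lies beyond the scatter above compound 1.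

Compound 4 `COc1cc(/C=C/C(=O)/C=C/c2ccccc2)ccc1OCc1cn(CCCCOc2cc(=O)oc3ccccc23)nn1` differs from compound 1 in one place: hydrogen in place of methoxy on an aromatic carbon. Going by the values given here, the only step measured so far, a number 16 percentage points lower from compound 2 to compound 3 (beyond the scatter), replaces the whole aromatic group on that chain carbon rather than a single substituent on it, so it bears only loosely on the present change. Among the compounds with values here, no measured step removes a methoxy alone. The step from compound 1 to compound 4 is therefore expected to be a number 2 percentage points lower from compound 1 to compound 4 (within the scatter), not beyond the scatter. Compound 4 is estimated at 38%, between 25% and 52%.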

Compound 4, percent growth inhibition at one concentration: 36%
Beside the measured number, compound 4's estimate is 2 percentage points above it; measured number inside the range.
By their numbers in this assay, from the lowest: compounds 4, 3 and 1 (each within the scatter of the next); then compound 2.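

In this assay, methoxy on this six-membered aromatic ring of carbon only gives way to hydrogen with a number 4 percentage points lower from compound 1 to compound 4 (within the scatter), so going from 2-methoxyphenyl to phenyl leaves the number within the scatter. Going by these compounds alone, this is the first step to change one substituent on such a ring rather than the whole aromatic group. Nothing measured here explains this result. As far as these compounds go, it remains open whether a hydroxy group, an amine or a fluorine on this aromatic carbon would depart from methoxy and hydrogen. Also open, from the compounds shown here alone, is whether a single methoxy change on the 3,4,5-trimethoxyphenyl of compound 2 would matter as little.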